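The compounds below may be only part of what the source reports. "The series", "measured", "known", "first", "only" and "open" are said of these compounds alone.

Working notes on the series in a functional assay on NCI-H292 cells (Homo sapiens) for inhibition, read by MTT assay, with a stated time of 72 h; a higher number here means a weaker inhibitor, a lower number a stronger inhibitor. Compound 2 `C#CCO[C@@H]1C=CC(=O)[C@@H](CO)O1` gives 6600 nM, compound 3 `CC(C)O[C@@H]1C=CC(=O)[C@@H](CO)O1` gives 24200 nM, and compound 1 `COCCOCCOCCO[C@@H]1C=CC(=O)[C@@H](CO)O1` gives 35500 nM. Compound 2 stands lowest of the three numbers, with compound 3 nearest and compound 1 furthest, both beyond the scatter. Compound 4 `C=CCO[C@@H]1C=CC(=O)[C@@H](CO)O1` differs from compound 2 by vinyl in place of ethynyl on a saturated chain carbon bound to an oxygen on a saturated carbon. For the measured compounds named here, no measured step matches this change exactly; the step of a 3.7-fold higher number from compound 2 to compound 3 (0.56 log units; beyond the scatter) is the only recorded change at this oxygen and the nearest guide, a modest weakening. From compound 2 a smaller rise of the same direction is expected, a 1.8-fold higher number from compound 2 to compound 4 (0.26 log units; within the scatter). Compound 4 is accordingly estimated at 12000 nM, with a range from 5000 nM to 30000 nM.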

Compound 4, half-maximal inhibitory concentration: 10300 nM
Estimate against measurement, compound 4: 1.2-fold (0.07 log units) above, within the range that was stated.
By their numbers in this assay, from the lowest: compounds 2 and 4 (each within the scatter of the next); then compounds 3 and 1 (each within the scatter of the next).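

In this assay propargyl and allyl on this oxygen cannot be told apart, with a 1.6-fold higher number from compound 2 to compound 4 (0.19 log units; within the scatter) showing that the triple bond can give way to a double bond within the scatter. Allyl and isopropyl do separate, with a 2.3-fold lower number from compound 3 to compound 4 (0.37 log units; beyond the scatter) as a modest step beyond the scatter. Nothing on hand accounts for either step. The compounds shown leave open whether unsaturation or branching separates allyl from isopropyl, a question that a straight propyl chain would address. On these data alone, how an amine at the end of the chain would read is also open.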